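Halogen swap on the aryl ring: cytotoxicity notes

A few compounds are considered here, and "the series" means these few. Any claim that something is new, unique, unknown or untested is made for them only; others in the source may bear on it.

Measured compounds:
- compound 1, `O=C(Nc1ncc(Cc2ccc(Cl)cc2)s1)c1cccs1`; in an ADME assay on HepG2 2.2.15 cells (Homo sapiens) for cytotoxicity (a lower number here means that less compound is tolerated, a higher number that more compound is tolerated), compound 1 gives > 50000 nM, a limit of the assay rather than a number.
- compound 2, `O=C(Nc1ncc(Cc2ccc(Br)cc2)s1)c1cccs1`; in this assay compound 2 gives > 50000 nM, again a limit.
- compound 3, `COc1ccc(C(=O)Nc2ncc(C(Oc3ccc4cc(Br)ccc4c3)c3ccc(Cl)cc3)s2)cc1`; in this assay compound 3 gives > 50000 nM, also a limit.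

Compound 1 and compound 2 share one core, and compound 2 differs from compound 1 by bromo in place of chloro on an aromatic carbon. The step that the two limits leave unreadable from compound 1 to compound 2 cannot be sized because the limit of > 50000 nM in this assay, at which 3 of the 3 values shown sit, holds both values. Compound 3 carries another core; the difference between the core of compound 1 and the core of compound 3 is not broken down here.

Compound 4, `COc1ccc(C(=O)Nc2ncc(C(Oc3ccc4cc(Br)ccc4c3)c3ccc(Br)cc3)s2)cc1`, is not yet measured in this assay. It differs from compound 3 by bromo in place of chloro on an aromatic carbon, which is the same change, at the same place, as that made from compound 1 to compound 2. For compound 4 the step that the limit leaves unreadable from compound 3 to compound 4 is expected to be small to nil, an expectation that rests on the measured pair, where the step that the two limits leave unreadable from compound 1 to compound 2 left both values at the limit of > 50000 nM in this assay, at which 3 of the 3 values shown sit, and on compound 3 sitting at that same limit. Compound 4 is therefore expected at 70000 nM, within a range from 30000 nM to 200000 nM, and most probably reported only as a limit.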

Compound 4, half-maximal cytotoxic concentration: > 50000 nM
Compound 4 ended at the assay's limit; the forecaster's own chance of this, stated with the estimate: 85%; the middle value is on the limit's open side.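

In this assay compound 4 gives > 50000 nM, a limit of the assay and not a number. No step can be read from compound 3 to compound 4, because both values are held at one limit: the limit of > 50000 nM in this assay, at which 4 of the 4 values shown sit. The compounds shown leave open at what concentration any of them becomes cytotoxic, and whether the change from 4-chlorophenyl to 4-bromophenyl alters that concentration.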